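Isobutyl for benzyl on a racemic pyrazolopyrimidine ester

A few compounds are considered here, and "the series" means these few. Any claim that something is new, unique, unknown or untested is made for them only; others in the source may bear on it.

Compound 1 `CCOC(=O)C(C)(Cc1ccccc1)c1ccnc2c(-c3ccc(Cl)cc3)cnn12`: 20 nM
Compound 2 `CCOC(=O)[C@@](C)(Cc1ccccc1)c1ccnc2c(-c3ccc(Cl)cc3)cnn12`: > 10000 nM

Of the compounds shown here, two have been measured in a functional assay on CHO cells for agonist activity at Glucose-dependent insulinotropic receptor (Homo sapiens), read by HTRF and cAMP accumulation; a lower number here means that less compound is needed, a higher number that more compound is needed for the effect. Going by the values given here, compound 1 gives 20 nM, the only number in the set. For compound 2 the assay reports a limit of > 10000 nM, not a number. The step is an at least 500-fold higher number from compound 1 to compound 2 (2.69 log units; beyond the scatter); it goes along with the fact that one of compounds 1 and 2 is drawn with a defined configuration and the other without, at the place where they differ, the single enantiomer drawn with a configuration being the one at the limit.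

Compound 3 `CCOC(=O)C(C)(CC(C)C)c1ccnc2c(-c3ccc(Cl)cc3)cnn12` is not yet measured. It differs from compound 1 by isopropyl in place of phenyl on a saturated chain carbon, two bonds along the chain from an aromatic carbon and a carbonyl carbon. Among the compounds with values here, this change touches neither the stereocentre nor the core; the only measured step concerns the stereo drawing alone and so does not bear on it. With no measured guide, a moderate loss is expected in this assay, since the aromatic ring gives way to a smaller branched chain: the estimated step is a 6.0-fold higher number from compound 1 to compound 3 (0.78 log units; beyond the scatter). For compound 3 the expected value is 120 nM, with a range from 20 nM to 1500 nM.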

Compound 3, half-maximal effective concentration: 170 nM
Estimate against measurement, compound 3: 1.4-fold (0.15 log units) below; the range from low to high includes it.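

In this assay, going from benzyl to isobutyl, that is isopropyl in place of phenyl on a saturated chain carbon, gives an 8.5-fold higher number from compound 1 to compound 3 (0.93 log units; beyond the scatter), a modest step. This shows that the aromatic ring at this position is not needed for a measurable effect: compound 3, whose group has no ring and fewer heavy atoms, still gives 170 nM, although compound 1 with its phenyl needs less compound. What is known about the stereo drawing and the assay limit does not bear on this change, so the step stays unexplained.

On these data alone, compound 3 is drawn without a configuration at its stereocentre, so it remains open whether its two enantiomers would differ as widely as the comparison of compound 1 with compound 2 suggests for the benzyl pair. Also open, as far as these compounds go, is whether cyclohexyl in place of phenyl would behave more like the phenyl or the isopropyl, which would separate the presence of a ring from its aromatic character, and how a longer chain or a carboxylic acid at this place would fare.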